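Swapping an ethyl for an ethoxy on an inactive pyranone chain

The compounds below may be only part of what the source reports. "The series", "measured", "known", "first", "only" and "open" are said of these compounds alone.

Compound 1, with structure `CCCCc1cc(C)oc(=O)c1`, was tested in a functional assay on K562 cells (Homo sapiens) for inhibition; a higher number here means a weaker inhibitor, a lower number a stronger inhibitor. In this assay compound 1 gives > 50000 nM, which is a limit of the assay rather than a measured number. Compound 2, with structure `Cc1cc(-c2ccc(Cl)cc2)cc(=O)o1`, was tested in the same assay. In this assay compound 2 also gives > 50000 nM, again a limit and not a number. So compound 1 does not stand at any point on a scale here; the two values shown both sit at the same limit, as the summary the limit of > 50000 nM in this assay, at which 2 of the 2 values shown sit, records, and neither compound shows measurable inhibition.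

Compound 3, with structure `CCOCCc1cc(C)oc(=O)c1`, has not yet been measured. It differs from compound 1 in one place: ethoxy in place of ethyl on a saturated chain carbon, two bonds along the chain from an aromatic carbon. Among the compounds with values here, no measured step between two compounds exists here, so the size of this change can only be guessed. Given that compound 1 gives > 50000 nM, the step in this assay a step that the limit leaves unreadable from compound 1 to compound 3 is expected to stay within the scatter, with compound 3 most likely also at the limit. Compound 3 is therefore estimated at 60000 nM, within a range from 20000 nM to 200000 nM.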

Compound 3, half-maximal inhibitory concentration: > 50000 nM
Compound 3 ended at the assay's limit (the forecaster's own chance of this, stated with the estimate: 85%); the middle value lies beyond the limit too.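

Within the data shown here, compound 1 and compound 3 both sit at a limit rather than at a measured number, so no step between them can be read, and the swap of ethyl for ethoxy has no size here. All the compounds shown end the same way: the limit of > 50000 nM in this assay, at which 3 of the 3 values shown sit.

From the compounds shown here alone, what stays open is whether any change to these structures gives measurable inhibition at all.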